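Halogenated Aryl Replaces Methoxyphenyl on a Cytotoxicity Scaffold

The source may report more compounds than this note shows. Statements on the series, on what has been measured and on what is new or still open speak of the compounds shown alone.

Measured compounds:
- Compound 1 `COc1ccc(-n2ccc(=O)c(C(=O)Nc3ccc(Oc4ccnc5[nH]ccc45)cc3)n2)cc1`: in a functional assay on HepG2 cells (Homo sapiens) for cytotoxicity, read by MTT assay, with a stated time of 72 h (a higher number here means a weaker inhibitor, a lower number a stronger inhibitor), compound 1 gives 50800 nM.
- Compound 2 `O=C(Nc1ccc(Oc2ccnc3[nH]ccc23)c(F)c1)c1nn(-c2ccc(Cl)cc2)ccc1=O`: in this assay compound 2 gives > 60000 nM, which is a limit of the assay and not a number.
- Compound 3 `COc1ccc(-n2ccc(=O)c(C(=O)Nc3ccc(Oc4ccnc5c4ccn5C)cc3)n2)cc1`: in this assay compound 3 gives > 60000 nM, again a limit of the assay and not a number.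

Compound 3 therefore stands at the weak end of what has been measured, with only a limit to its name. Among the measured compounds shown here, the single one-place step that reaches it, an at least 1.1-fold higher number from compound 1 to compound 3 (0.07 log units; that floor lies within the scatter), rests on that limit and cannot be sized more closely; the broader picture is given by the limit of > 60000 nM in this assay, at which 2 of the 3 values shown sit.

Compound 4 `Cn1ccc2c(Oc3ccc(NC(=O)c4nn(-c5ccc(Br)cc5F)ccc4=O)cc3)ccnc21` differs from compound 3 in one place: 4-bromo-2-fluorophenyl in place of 4-methoxyphenyl on an aromatic nitrogen. For the measured compounds named here, no measured step follows this change directly. Compound 2, which carries a halogenated aryl on the same nitrogen, shows a limit, and compound 1 with the methoxyphenyl shows a number close to that limit, so the two values shown for this kind of aryl give no sign that a halogenated ring makes a stronger inhibitor. Compound 4 is therefore expected to stay at or beyond the limit, with a step that the limit leaves unreadable from compound 3 to compound 4 amounting to no step beyond the scatter. The estimate for compound 4 is 80000 nM, with a range from 40000 nM to 200000 nM.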

Compound 4, half-maximal inhibitory concentration: 31200 nM
The estimate for compound 4 lay 2.6-fold (0.41 log units) above the measured number; the measured number lies below the stated range.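

Among the compounds shown here, this is the first measured step that touches the aryl on this nitrogen of the core, and 4-bromo-2-fluorophenyl in place of 4-methoxyphenyl gives an at least 1.9-fold lower number from compound 3 to compound 4 (0.28 log units; that floor lies within the scatter). Compound 4 thereby gives a read number in this assay, 31200 nM, so this position accepts the exchange of one aryl for another. The change can be sized only as a floor, which may understate it, because the step starts from a limit of the assay, and that floor does not by itself show a change beyond the scatter: the limit of > 60000 nM in this assay, at which 2 of the 4 values shown sit.

The compounds shown do not separate the part played by the bromine from that of the fluorine on this ring, and they leave open how the same exchange reads on the core with hydrogen in place of the methyl. As far as these compounds go, what an amine or a carboxylic acid on this aryl ring would do to the value also remains open, as does the effect of a longer chain in place of the methyl on the core.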